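A few compounds are considered here, and "the series" means these few. Any claim that something is new, unique, unknown or untested is made for them only; others in the source may bear on it.

In an ADME assay on microsomes from liver (Homo sapiens) for metabolic stability, read by LC-MS, with a stated time of 10 min (on this read-out higher numbers stand for a more stable compound and lower numbers for a less stable compound), compound 1 (`c1cnc2c(c1)CCC[C@@H]2N(CC1CC1)C[C@H]1Cc2c(cccc2N2CCNCC2)CN1`) gives 82.1%, the second highest of three measured numbers. Compound 2 (`CN(C[C@@H]1Cc2c(cccc2N2CCNCC2)CN1)[C@H]1CCCc2cccnc21`) stands higher at 94.2% and compound 3 (`CN(C[C@H]1Cc2c(cccc2N2CCN3CCC[C@H]3C2)CN1)[C@H]1CCCc2cccnc21`) lower at 36.6%, both gaps to compound 1 lying beyond the usual scatter. The next step leads to compound 4 (`FC1(F)CCC(CN(C[C@H]2Cc3c(cccc3N3CCNCC3)CN2)[C@H]2CCCc3cccnc32)CC1`): 4,4-difluorocyclohexyl in place of cyclopropyl on a saturated chain carbon bound to an amine nitrogen. Among the measured compounds shown here, no measured pair isolates a change at this place, so the expectation is loose: a moderate fall in this assay, somewhat beyond the scatter. The estimated change is a number 14.1 percentage points lower from compound 1 to compound 4 (beyond the scatter). For compound 4 the expected value is 68%, with an estimated range of 45% to 88%.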

Compound 4, percent of the compound remaining: 68.6%
Compound 4: the middle estimate sits 0.6 percentage points below what was measured; measured number inside the range.
By their numbers in this assay, from the lowest: compound 3; then compound 4; then compound 1; then compound 2.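

In this assay, 4,4-difluorocyclohexyl in place of cyclopropyl on a saturated chain carbon bound to an amine nitrogen gives a number 13.5 percentage points lower from compound 1 to compound 4 (beyond the scatter) as the first pair isolating this place. The read-out therefore responds to this substituent, though the change from cyclopropylmethyl to (4,4-difluorocyclohexyl)methyl leaves the fall modest. No available data account for this fall. Whether it follows the larger ring or the fluorine atoms stays open, with unfluorinated cyclohexyl absent from the compounds shown. Also open, from the compounds shown here alone, is how a chain carrying an amine or a carboxylic acid would read here.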